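From sec-butyl to butyl on an amine nitrogen

This account rests on a few compounds, and the source may have more. Where it says the series, first, only, none or still open, it means among the compounds named here.

In a functional assay on HT-29 cells (Homo sapiens) for inhibition, read by MTT assay, with a stated time of 72 h (a higher number here means a weaker inhibitor, a lower number a stronger inhibitor), compound 1 `CCC(C)NC(=C\C(=O)/C=C/c1ccc(O)c(OC)c1)/C=C/c1ccc(O)c(OC)c1` gives > 25000 nM, which is a limit of the assay and not a number. Two relatives do give numbers. Compound 2 `CC(=O)Oc1ccc(/C=C/C(=O)/C=C(/C=C/c2ccc(OC(C)=O)cc2)NCC(C)C)cc1` reads 13700 nM, and compound 3 `O=C(/C=C(/C=C/c1ccc(O)cc1)NC1CCCCC1)/C=C/c1ccc(O)cc1` reads 4000 nM. Neither differs from compound 1 in one place only, so they offer no direct measure of a change at the amine nitrogen.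

Compound 4 `CCCCNC(=C\C(=O)/C=C/c1ccc(O)c(OC)c1)/C=C/c1ccc(O)c(OC)c1` has not yet been measured. It has the same atoms as compound 1, joined differently: butyl in place of sec-butyl on an amine nitrogen. The rest of the structure stays the same.

Going by the values given here, no measured pair shows this change, so any expectation in this assay is loose. Compound 2, at 13700 nM, suggests that a measurable number is possible within this family. Compound 4 could also end at the limit of the assay. A small step toward stronger inhibition is expected, perhaps none beyond the scatter. The estimated change is an at least 1.2-fold lower number from compound 1 to compound 4 (0.09 log units; that floor lies within the scatter). For compound 4 the expected value is 20000 nM, with an estimated range from 8000 nM to 45000 nM.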

Compound 4, half-maximal inhibitory concentration: 19700 nM
Estimate against measurement, compound 4: 1.0-fold (0.01 log units) above; the measured number falls inside the stated range.
By their numbers in this assay, from the lowest: compound 3; then compounds 2 and 4 (each within the scatter of the next). At a limit, above all of these: compound 1.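

In this assay, going by these compounds alone, the change on the amine nitrogen now has its first direct reading, which the earlier compounds could not give: butyl in place of sec-butyl yields an at least 1.2-fold lower number from compound 1 to compound 4 (0.10 log units; that floor lies within the scatter). For compound 1, > 25000 nM is a limit and not a number. The step is therefore only a floor, and that floor lies within the scatter, so the pair shows that a number can be obtained with butyl on this nitrogen but does not fix the size of the change, because one end of the step rests on a limit: the limit of > 25000 nM in this assay, at which 1 of the 4 values shown sits.

The compounds shown leave open how a longer chain such as hexyl, or a benzyl group, on the amine nitrogen would read on the core of compound 1, and so whether the chain on this nitrogen can move the number well beyond the scatter. From the compounds shown here alone, compound 2 and compound 3 each differ from compound 4 in more than one place, so steps to them cannot be read, and whether butyl would give a similar change on their cores also remains open.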